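The source may hold more compounds than are shown below. What is called first, only, known or untested is meant among the compounds shown, and "the series" means these compounds.

Three compounds built on a shared core were measured in a functional assay on UACC-257 cells (Homo sapiens) for cytotoxicity, read by sulforhodamine B assay, with a stated time of 48 h, tested at 0.01 uM; a lower number here means a stronger effect, a higher number a weaker effect of the compound at the concentration tested. In that assay compound 1 `COc1cc(-c2cc(/C=C/C(=O)c3ccc(N)cc3)[nH]n2)cc(OC)c1OC` gives 94%, compound 2 `COc1cc(-c2cc(/C=C/C(=O)c3ccc(Cl)c(Cl)c3)[nH]n2)cc(OC)c1OC` gives 96% and compound 3 `COc1ccc(C(=O)/C=C/c2cc(-c3cc(OC)c(OC)c(OC)c3)n[nH]2)cc1OC` gives 85%. Compound 3 shows the lowest of the three numbers: the step of a number 9 percentage points lower from compound 1 to compound 3 (within the scatter) lies within the scatter, while a number 11 percentage points lower from compound 2 to compound 3 (beyond the scatter) lies just beyond it. Compound 4 `COc1cc(C(=O)/C=C/c2cc(-c3cc(OC)c(OC)c(OC)c3)n[nH]2)cc(OC)c1OC` differs from compound 3 by methoxy in place of hydrogen on an aromatic carbon. Every measured step exchanges the group on the carbonyl carbon, and a number 2 percentage points higher from compound 1 to compound 2 (within the scatter) as well as the two steps onto compound 3 were small, so a further change at that group is expected to move this assay by no more than the scatter. Compound 4 is therefore estimated at 85%, between 74% and 96%. The expected step of no change at the digits printed from compound 3 to compound 4 (within the scatter) is thus a small one.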

Compound 4, a percentage reported as activity, at one concentration (the size of the read-out at that concentration, not a potency): 94%
The estimate for compound 4 lay 9 percentage points below the measured number; the range from low to high includes it.
By their numbers in this assay, from the lowest: compounds 3, 1, 4 and 2 (each within the scatter of the next, the first and the last beyond it).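

Unlike the earlier steps, which exchanged the whole group on the carbonyl carbon, this change alters a single place on that group: methoxy in place of hydrogen, ortho to a methoxy group and meta to a large group. In this assay, a number 9 percentage points higher from compound 3 to compound 4 (within the scatter), so the added methoxy at this place brings no change that can be told from the scatter. No available measurement explains this result. On these data alone, whether a hydroxyl group, an amine or a longer chain such as ethoxy at this place would move the number beyond the scatter stays open.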